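This account rests on a few compounds, and the source may have more. Where it says the series, first, only, none or still open, it means among the compounds named here.

Three compounds share one core and differ only in the group on an oxygen on an aromatic ring. Compound 1 `COCC(C)Oc1cccc2ccc(N)nc12` gives 606 nM in an assay on cells with melanin-concentrating hormone receptor 1 (Homo sapiens) as the target, read by radioligand binding (on this read-out lower numbers stand for stronger inhibition and higher numbers for weaker inhibition), the highest of the three numbers measured. Compound 2 `Nc1ccc2cccc(OCC3CCCC3)c2n1` gives 53 nM in this assay, and compound 3 `COC(C)(C)CCOc1cccc2ccc(N)nc12` gives 132 nM. The step of an 11-fold lower number from compound 1 to compound 2 (1.06 log units; beyond the scatter) is large, while the step of a 2.5-fold higher number from compound 2 to compound 3 (0.40 log units; beyond the scatter) is modest.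

Compound 4 `CC(C)=CCOc1cccc2ccc(N)nc12` has not yet been measured. It differs from compound 1 in one place: 3-methylbut-2-en-1-yl in place of 1-(methoxymethyl)ethyl on an oxygen on an aromatic ring. Like compound 2, compound 4 carries a group made only of carbon, with no hydrogen-bond acceptor, so the step of an 11-fold lower number from compound 1 to compound 2 (1.06 log units; beyond the scatter) bears most directly on it, and the step of a 2.5-fold higher number from compound 2 to compound 3 (0.40 log units; beyond the scatter), where an oxygen returns to the chain, suggests a chain without oxygen is favoured. A clear drop in number is therefore expected for compound 4 in this assay, though the group is neither a ring nor branched at the carbon bound to oxygen, so the full size of the step to compound 2 need not be reached. Compound 4 is expected to give about 110 nM in this assay, within a range from 35 nM to 350 nM, which means an expected step of a 5.5-fold lower number from compound 1 to compound 4 (0.74 log units; beyond the scatter).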

Compound 4, half-maximal inhibitory concentration: > 2000 nM
Compound 4 ended at the assay's limit; the forecaster's own chance of this, stated with the estimate: 2%; at least 18-fold (1.25 log units) between middle value and limit.
By their numbers in this assay, from the lowest: compound 2; then compound 3; then compound 1. At a limit, above all of these: compound 4.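

In this assay compound 4 stands at a limit of the assay, not at a number: the limit of > 2000 nM in this assay, at which 1 of the 4 values shown sits.

This shows that a group made only of carbon does not by itself lower the number at this oxygen: 3-methylbut-2-en-1-yl gives an at least 3.3-fold higher number from compound 1 to compound 4 (0.51 log units; beyond the scatter), even though compound 2 also has no hydrogen-bond acceptor in its group. Among these compounds, the other steps are an at least 37-fold higher number from compound 2 to compound 4 (1.57 log units; beyond the scatter) and an at least 15-fold higher number from compound 3 to compound 4 (1.18 log units; beyond the scatter), so the group with a methoxy in its chain now reads lower than this group without oxygen, which reverses what the earlier compounds suggested.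

Still open, as far as these compounds go, is whether the double bond or the open chain accounts for the loss, a question that a saturated 3-methylbutyl group on the same oxygen would address. From the compounds shown here alone, how a chain carrying an amine or a carboxylic acid would read also remains open.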